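Compound 3 to compound 4: 4-methylbenzyl for 2-fluorobenzyl

The source may report more compounds than this note shows. Statements on the series, on what has been measured and on what is new or still open speak of the compounds shown alone.

Working notes on a physicochemical assay for solubility, in phosphate buffer (a lower number here means a less soluble compound, a higher number a more soluble compound), follow. Compound 1 `Cc1cc(S(=O)(=O)NCCCC[C@@H](Nc2cc(C)c(F)c(C)c2)C(=O)NO)ccc1F` gives > 5 ug/mL and this is a limit of the assay. Compound 2 `Cc1cc(NC(=O)NCCCC[C@@H](Nc2cc(C)c(F)c(C)c2)C(=O)NO)ccc1F` gives > 5 ug/mL and this too is a limit. Compound 3 `Cc1cc(N[C@H](CCCCNCc2ccccc2F)C(=O)NO)cc(C)c1F` stands at > 5 ug/mL and this also is only a limit. Among the measured compounds shown here, the series so far shows the limit of > 5 ug/mL in this assay, at which 3 of the 3 values shown sit, and offers no measured step. Compound 4 `Cc1ccc(CNCCCC[C@@H](Nc2cc(C)c(F)c(C)c2)C(=O)NO)cc1` differs from compound 3 as follows: 4-methylphenyl in place of 2-fluorophenyl on a saturated chain carbon bound to an amine nitrogen and in short, 4-methylphenyl in place of 2-fluorophenyl on a saturated chain carbon bound to an amine nitrogen. The expected change, a step that the limit leaves unreadable from compound 3 to compound 4 is none beyond the scatter, in either direction. Compound 4 is estimated at 8 ug/mL with an expected range of 5 ug/mL to 20 ug/mL for the reading.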

Compound 4, solubility: > 5 ug/mL
Compound 4 gave a limit, no number; the forecaster's own chance of this, stated with the estimate: 75%; the middle value is on the limit's open side.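

Compound 3 and compound 4 give no readable step in this assay: the limit of > 5 ug/mL in this assay, at which 4 of the 4 values shown sit.

The compounds shown leave open where any of them actually lies past that limit, and so whether 4-methylphenyl in place of 2-fluorophenyl changes the reading at all.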